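Chloro in place of hydrogen on the benzoyl ring

The compounds below may be only part of what the source reports. "The series", "measured", "known", "first", "only" and "open" are said of these compounds alone.

Measured so far:
compound 1 `Nc1scc(-c2cccc(C(F)(F)F)c2)c1C(=O)c1ccccc1` — 59%
compound 2 `Nc1scc(-c2cc(C(F)(F)F)cc(C(F)(F)F)c2)c1C(=O)c1ccccc1` — 93%

In a functional assay on CHO cells for agonist activity at adenosine receptor A1 (Homo sapiens), read by fluorescence and ERK phosphorylation, with stated times of 30 min and 1.5 h, tested at 10 uM (on this read-out lower numbers stand for a weaker effect and higher numbers for a stronger effect at the one concentration tested), compound 1 gives 59% and compound 2 gives 93%. Among the measured compounds shown here, compound 2 stands highest of the two numbers, the only measured step being a number 34 percentage points higher from compound 1 to compound 2 (beyond the scatter), a large rise that comes with trifluoromethyl in place of hydrogen on an aromatic carbon. Compound 3 `Nc1scc(-c2cc(C(F)(F)F)cc(C(F)(F)F)c2)c1C(=O)c1ccc(Cl)cc1` differs from compound 2 by chloro in place of hydrogen on an aromatic carbon. For the measured compounds named here, no measured step concerns the benzoyl side, so nothing bears directly on this change; the step from compound 1 to compound 2 sits on the other ring and gives no guide here. With compound 2 already high, the expected step of a number 8 percentage points lower from compound 2 to compound 3 (within the scatter) is small and within the scatter, with more room downward than upward. The estimate for compound 3 is 85%, in a range from 60% to 100%.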

Compound 3, a percentage reported as activity, at one concentration (the size of the read-out at that concentration, not a potency): 74%
Compound 3: the middle estimate sits 11 percentage points above what was measured; the measured number falls inside the stated range.
By their numbers in this assay, from the lowest: compound 1; then compound 3; then compound 2.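

The benzoyl ring is not a silent position in this assay: chloro in place of hydrogen, on an aromatic carbon para to a large group, gives a number 19 percentage points lower from compound 2 to compound 3 (beyond the scatter). The first change shown on this ring therefore runs downward, opposite in direction to a number 34 percentage points higher from compound 1 to compound 2 (beyond the scatter) on the other ring, and a single added chlorine atom is enough to move the number beyond the scatter. No supporting measurement bears on why the number falls.

Whether the fall belongs to chloro itself or to this place on the ring remains open, as the benzoyl ring is shown with only this one substituent. Fluoro, methoxy or an amine on the same carbon would separate these, and since each number comes from one concentration, potency also remains open.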